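Nucleoside analogues with a branched sugar substituent: cell-growth inhibition

The compounds below may be only part of what the source reports. "The series", "measured", "known", "first", "only" and "open" are said of these compounds alone.

Measured so far:
compound 1 `C#CC[C@]1(O)[C@@H](CO)O[C@@H](n2ccc(=O)[nH]c2=O)[C@@H]1O` — > 350000 nM
compound 2 `C=C[C@@]1(O)[C@@H](CO)O[C@@H](n2ccc(N)nc2=O)[C@@H]1O` — 74300 nM
compound 3 `CCC[C@@]1(O)[C@@H](CO)O[C@@H](n2ccc(=O)[nH]c2=O)[C@@H]1O` — > 350000 nM

In a functional assay on KB cells (Homo sapiens), read by MTT assay (a lower number here means a stronger inhibitor, a higher number a weaker inhibitor), compound 3 gives only a limit, > 350000 nM, not a number. Compound 1 likewise gives only a limit in this assay, > 350000 nM. Within the data shown here, compound 2, the one value reported as a number, gives 74300 nM in this assay. Two of the three values shown sit at the same place: the limit of > 350000 nM in this assay, at which 2 of the 3 values shown sit.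

The next compound, compound 4 `CC#C[C@@]1(O)[C@@H](CO)O[C@@H](n2ccc(=O)[nH]c2=O)[C@@H]1O`, differs from compound 3 by prop-1-yn-1-yl in place of propyl on a saturated ring carbon. Among the measured compounds shown here, no step between measured compounds is available for this change. Compound 4 is expected to stay at or near the limit in this assay, so the step of a number no higher from compound 3 to compound 4 (the limit leaves the size open) is expected to be none beyond the scatter. The estimate for compound 4 is 350000 nM, within 100000 nM to 1000000 nM.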

Compound 4, half-maximal inhibitory concentration: 70800 nM
For compound 4 the middle estimate is 4.9-fold (0.69 log units) above the measured one, and the stated range ends above it.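

In this assay, prop-1-yn-1-yl in place of propyl on this saturated ring carbon gives an at least 4.9-fold lower number from compound 3 to compound 4 (0.69 log units; beyond the scatter). With the same three carbons in the group, the triple bond alone is enough to take the compound off the limit. Compound 3 gives a limit and not a number, so the step has only a lower bound, and that limit is shared: the limit of > 350000 nM in this assay, at which 2 of the 4 values shown sit.

The compounds shown leave open whether a longer chain ending in a triple bond, or an amine on this carbon, would keep this activity. On these data alone, whether the same change acts alike with the base of compound 2 also remains open.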